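This account rests on a few compounds, and the source may have more. Where it says the series, first, only, none or still open, it means among the compounds named here.

In a functional assay on HCT-116 cells (Homo sapiens) for antiproliferative activity, read by sulforhodamine B assay, with a stated time of 4 days (on this read-out lower numbers stand for stronger inhibition of growth and higher numbers for weaker inhibition of growth), compound 1 `COc1cc(Cl)c(-c2nc(SCC(=O)NC3CC3)nc3[nH]cc(C#N)c23)cc1O` gives 1160 nM, compound 2 `CCOc1cc(-c2nc(SCC(=O)NC3CC3)nc3[nH]cc(C#N)c23)c(Cl)cc1OC` gives 20 nM and compound 3 `COc1cc(Cl)c(-c2nc(SCC(=O)NC(C)C)nc3[nH]cc(C#N)c23)cc1O` gives 238 nM, the middle of the three numbers. Compound 4 `COc1cc(Cl)c(-c2nc(SCC(=O)NC(C)C)nc3[nH]cc(C#N)c23)cc1OC` has not yet been measured. It differs from compound 3 by methyl in place of hydrogen on an oxygen on an aromatic ring, turning hydroxy into methoxy. Within the data shown here, the closest precedent is the large 58-fold lower number from compound 1 to compound 2 (1.76 log units; beyond the scatter), where ethyl replaced that hydrogen. The modest 4.9-fold lower number from compound 1 to compound 3 (0.69 log units; beyond the scatter), with isopropyl in place of cyclopropyl on an amide-type nitrogen, shows that compound 3 carries a different amide substituent from that precedent. Among the measured compounds shown here, no measured pair tests methyl itself, or any change on this oxygen with isopropyl present. A large move toward a lower number in this assay is therefore expected, perhaps somewhat smaller than the ethyl step. The expected step is a 24-fold lower number from compound 3 to compound 4 (1.38 log units; beyond the scatter). Compound 4 is estimated at 10 nM, with an expected range from 3 nM to 40 nM.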

Compound 4, concentration for 50% growth inhibition: 81 nM
Compound 4: middle estimate off by 8.1-fold (0.91 log units), on the low side; measured number outside the range, above it.
By their numbers in this assay, from the lowest: compound 2; then compound 4; then compound 3; then compound 1.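

Among these compounds, with the isopropyl amide present, methyl on this oxygen gives a 2.9-fold lower number from compound 3 to compound 4 (0.47 log units; beyond the scatter) in this assay and so supplies the first measured step for methoxy. The lower number on replacing the hydrogen of this hydroxy is thus seen with methyl as well as ethyl and with both amide substituents, although the earlier ethyl step (a 58-fold lower number from compound 1 to compound 2 (1.76 log units; beyond the scatter)) is the larger of the two. No evidence is at hand that accounts for the difference in size.

The compounds shown leave open whether that difference follows from methyl versus ethyl on the oxygen or from isopropyl versus cyclopropyl on the amide nitrogen, as neither group on the oxygen appears with both amides. They also say nothing about a longer chain such as propyl on this oxygen, or about an amine in place of the hydroxy.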